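Aryl-to-alkyl swap on the five-membered ring

A few compounds are considered here, and "the series" means these few. Any claim that something is new, unique, unknown or untested is made for them only; others in the source may bear on it.

Working notes on a three-compound set sharing one core, all read in a functional assay on HepG2 cells (Homo sapiens) for antiproliferative activity, read by MTT assay, with a stated time of 72 h; on this read-out lower numbers stand for stronger inhibition and higher numbers for weaker inhibition. Compound 1 `O=C1O[C@H]([C@@H](O)Cn2cc(CNS(=O)(=O)c3ccc(F)cc3)nn2)C(OCc2ccccc2)=C1OCc1ccccc1` gives 18300 nM. Compound 2 `Cc1ccc(-c2cn(C[C@H](O)[C@H]3OC(=O)C(OCc4ccccc4)=C3OCc3ccccc3)nn2)cc1` gives 8770 nM, and compound 3 `CCCCCc1ccc(-c2cn(C[C@H](O)[C@H]3OC(=O)C(OCc4ccccc4)=C3OCc3ccccc3)nn2)cc1` gives 7460 nM. Compound 3 shows the lowest number of the three, but its gap to compound 2 lies within the scatter, so the two cannot be ordered; only compound 1 stands apart beyond the scatter.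

The measured steps: a 2.1-fold lower number from compound 1 to compound 2 (0.32 log units; beyond the scatter), a 2.5-fold lower number from compound 1 to compound 3 (0.39 log units; beyond the scatter), and a 1.2-fold lower number from compound 2 to compound 3 (0.07 log units; within the scatter). Both steps away from compound 1 are modest and point the same way; the chain extension between compound 2 and compound 3 changes nothing beyond the scatter.

Compound 4 `CCCCc1cn(C[C@H](O)[C@H]2OC(=O)C(OCc3ccccc3)=C2OCc2ccccc2)nn1` is the next case. The change from compound 3 is butyl in place of 4-pentylphenyl on an aromatic carbon. Within the data shown here, none of the measured steps removes the six-membered aromatic ring of carbon only, so the step has no direct precedent. The steps from compound 1 show that the group at this position can move the number modestly, and the chain-length step shows it can also leave it unchanged. A modest step toward a higher number is expected, of a size near the two steps from compound 1, though a flat outcome cannot be excluded. The expected step is a 1.7-fold higher number from compound 3 to compound 4 (0.24 log units; within the scatter). For compound 4 the estimate is 13000 nM, within a range of 5500 nM to 32000 nM.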

Compound 4, half-maximal inhibitory concentration: 32800 nM
Compound 4: middle estimate off by 2.5-fold (0.40 log units), on the low side, and the stated range ends below it.
By their numbers in this assay, from the lowest: compounds 3 and 2 (each within the scatter of the next); then compounds 1 and 4 (each within the scatter of the next).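

In this assay, among these compounds, the change at this aromatic carbon of the five-membered aromatic ring that removes the six-membered aromatic ring of carbon only is the first to give a step clearly larger than the scatter: butyl in place of 4-pentylphenyl gives a 4.4-fold higher number from compound 3 to compound 4 (0.64 log units; beyond the scatter), and butyl in place of 4-methylphenyl gives a 3.7-fold higher number from compound 2 to compound 4 (0.57 log units; beyond the scatter). The group at this position therefore does more than the earlier chain-length step showed, since compound 2 and compound 3, which both keep that ring, cannot be ordered, while butyl stands apart from both. The ring alone does not settle the matter, however: compound 1 also holds such a ring within its (((4-fluorophenyl)sulfonyl)amino)methyl group, yet a 1.8-fold higher number from compound 1 to compound 4 (0.25 log units; within the scatter) lies within the scatter, so compound 1 and compound 4 cannot be ordered.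

Nothing at hand gives a reason for these steps. As far as these compounds go, it remains open whether plain phenyl would fall with compound 2 and compound 3, and whether an octyl chain would stay with compound 4 or close the gap to them.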